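A few compounds are considered here, and "the series" means these few. Any claim that something is new, unique, unknown or untested is made for them only; others in the source may bear on it.

Of the compounds shown here, three on a shared core have so far been tested in a functional assay on Bel7402/5-FU cells (Homo sapiens) for cytotoxicity, read by MTT assay, with a stated time of 72 h (a higher number here means a weaker inhibitor, a lower number a stronger inhibitor), and their numbers lie close together. Compound 1 `O=C1C=CCC/C1=C\C=C\c1ccccc1` gives 4200 nM and compound 2 `Cc1ccc(/C=C/C=C2\CCC=CC2=O)cc1` gives 5800 nM while compound 3 `O=C1C=CCC/C1=C\C=C\c1ccc(Br)cc1` gives 4300 nM and so stands level with both of the others within the scatter. Compound 4 `O=C1C=CCC/C1=C\C=C\c1ccc([N+](=O)[O-])cc1` has not yet been measured. It carries nitro in place of bromo on an aromatic carbon, para to a large group, and nitro in place of bromo on an aromatic carbon sets out that change in full. For the measured compounds named here, three measured steps bear on it. There is a 1.0-fold higher number from compound 1 to compound 3 (0.01 log units; within the scatter) for bromo in place of hydrogen on an aromatic carbon, then a 1.4-fold higher number from compound 1 to compound 2 (0.14 log units; within the scatter) for methyl in place of hydrogen on an aromatic carbon, and finally a 1.3-fold lower number from compound 2 to compound 3 (0.13 log units; within the scatter) for bromo in place of methyl on an aromatic carbon. All three stay within the scatter, but none of them involves nitro, so the range has to stay wide. In this assay the estimated step for compound 4 is a 1.1-fold lower number from compound 3 to compound 4 (0.03 log units; within the scatter) and thus none beyond the scatter. Compound 4 is estimated at 4000 nM with an expected range from 1500 nM to 9000 nM as its upper end.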

Compound 4, half-maximal inhibitory concentration: 4500 nM
The estimate for compound 4 lay 1.1-fold (0.05 log units) below the measured number, and the stated range covers the measured number.
By their numbers in this assay, from the lowest: compounds 1, 3, 4 and 2 (each within the scatter of the next).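

Of the groups shown on this aromatic carbon, para to a large group, only nitro brings hydrogen-bond acceptors, and it also holds more heavy atoms than the bromine it replaces. Even so, in this assay the change to nitro gives a 1.0-fold higher number from compound 3 to compound 4 (0.02 log units; within the scatter) and the comparison with methyl gives a 1.3-fold lower number from compound 2 to compound 4 (0.11 log units; within the scatter) while the comparison with hydrogen gives a 1.1-fold higher number from compound 1 to compound 4 (0.03 log units; within the scatter) and all three steps stay within the scatter. Hydrogen, methyl, bromo and nitro at this place therefore cannot be told apart in this assay, and none of the four compounds goes against that reading. No evidence at hand accounts for this flat result.

Whether an amine, a carboxylic acid or a longer chain at this place would also stay within the scatter remains open, since all the groups shown here leave the number unchanged within it. From the compounds shown here alone, it also remains open whether the same holds for any of these groups at another place on the aromatic ring, or for changes to the shared core itself.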